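The source may report more compounds than this note shows. Statements on the series, on what has been measured and on what is new or still open speak of the compounds shown alone.

Three compounds share one core and differ only in the group carried on one outer aromatic ring. Compound 1 `Cc1ccc(-c2ccc(F)cc2)n1-c1ccc(-c2nc3ccccc3s2)cc1` carries fluoro, compound 2 `COc1ccc(-c2ccc(C)n2-c2ccc(-c3nc4ccccc4s3)cc2)cc1` carries methoxy and compound 3 `Cc1ccc(-c2ccc([N+](=O)[O-])cc2)n1-c1ccc(-c2nc3ccccc3s2)cc1` carries nitro. In a functional assay on MCF7 cells (Homo sapiens) for cytotoxicity, read by MTT assay, with a stated time of 72 h (on this read-out higher numbers stand for weaker inhibition and lower numbers for stronger inhibition), compound 1 gives 3180 nM, compound 2 gives 3260 nM, and compound 3 gives 3110 nM. Compound 3 shows the lowest of the three numbers, but the steps of a 1.0-fold lower number from compound 1 to compound 3 (0.01 log units; within the scatter) and a 1.0-fold lower number from compound 2 to compound 3 (0.02 log units; within the scatter) both lie within the scatter, as does a 1.0-fold higher number from compound 1 to compound 2 (0.01 log units; within the scatter), so the three compounds cannot be told apart on these numbers.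

Compound 4 `COc1ccc2nc(-c3ccc(-n4c(C)ccc4-c4ccc([N+](=O)[O-])cc4)cc3)sc2c1` keeps the nitro of compound 3 and adds a change on a different part of the core: methoxy in place of hydrogen on an aromatic carbon. For the measured compounds named here, none of the measured steps touches this fused ring; all three concern the other outer ring, and all three were flat. Going by the values given here, on that evidence, with no direct precedent, the expected step is small or none beyond the scatter, a 1.0-fold lower number from compound 3 to compound 4 (0.00 log units; within the scatter). The estimate for compound 4 in this assay is 3100 nM, with a range from 1200 nM to 8000 nM.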

Compound 4, half-maximal inhibitory concentration: 4520 nM
Beside the measured number, compound 4's estimate is 1.5-fold (0.16 log units) below it, within the range that was stated.
By their numbers in this assay, from the lowest: compounds 3, 1, 2 and 4 (each within the scatter of the next).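

For the compounds shown here, this is the first change on the fused system of two rings rather than on the other outer ring, and methoxy in place of hydrogen on an aromatic carbon there gives a 1.5-fold higher number from compound 3 to compound 4 (0.16 log units; within the scatter) in this assay. The two compounds therefore cannot be told apart, so with the nitro group kept, this position carries a methoxy group with no difference that these numbers can resolve. No measurement offered here bears on why the two numbers sit where they do.

Still open, on these data alone, is whether any other group at this position, such as an amine, a hydroxyl or a carboxylic acid, would give a step beyond the scatter. Also open, as far as these compounds go, is whether methoxy here would give the same result with fluoro in place of nitro on the other outer ring.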